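Replacing dimethylamino with methyl: compound 3 to compound 4

A few compounds are considered here, and "the series" means these few. Any claim that something is new, unique, unknown or untested is made for them only; others in the source may bear on it.

Measured in a functional assay on HL-60 cells (Homo sapiens) for cytotoxicity, with a stated time of 24 h; a higher number here means that more compound is tolerated, a lower number that less compound is tolerated:
- Compound 1 `O=C1/C(=C/c2ccc(F)cc2)CCC/C1=C\c1ccc([N+](=O)[O-])cc1`: 32000 nM
- Compound 2 `O=C1/C(=C/c2ccc(Cl)cc2)CCC/C1=C\c1ccc([N+](=O)[O-])cc1`: 4100 nM
- Compound 3 `CN(C)c1ccc(/C=C2\CCC/C(=C\c3ccc([N+](=O)[O-])cc3)C2=O)cc1`: > 400000 nM, a limit and not a number

Compound 3 stands highest of the three in this assay, though only a limit is known for it. The measured steps place it there: an at least 12-fold higher number from compound 1 to compound 3 (1.09 log units; beyond the scatter), and an at least 97-fold higher number from compound 2 to compound 3 (1.98 log units; beyond the scatter). The other measured step, a 7.8-fold lower number from compound 1 to compound 2 (0.89 log units; beyond the scatter), shows that the two halogens also differ from each other.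

Compound 4 `Cc1ccc(/C=C2\CCC/C(=C\c3ccc([N+](=O)[O-])cc3)C2=O)cc1` has methyl in place of dimethylamino on an aromatic carbon, para to a large group: methyl in place of dimethylamino on an aromatic carbon. The two steps that bring dimethylamino in bear most directly on this change, read in reverse. Both were large, so a large move to a lower number is expected once dimethylamino leaves. The expected step is an at least 26-fold lower number from compound 3 to compound 4 (1.42 log units; beyond the scatter). Compound 4 is estimated at 15000 nM, with an expected range from 3000 nM to 70000 nM.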

Compound 4, half-maximal cytotoxic concentration: 27000 nM
Compound 4: the middle estimate sits 1.8-fold (0.26 log units) below what was measured; the range from low to high includes it.
By their numbers in this assay, from the lowest: compound 2; then compounds 4 and 1 (each within the scatter of the next). At a limit, above all of these: compound 3.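

In this assay methyl falls with fluoro and not with dimethylamino, with a 1.2-fold lower number from compound 1 to compound 4 (0.07 log units; within the scatter) as the step between them. Chloro stays apart, with a 6.6-fold higher number from compound 2 to compound 4 (0.82 log units; beyond the scatter) as its step, so the groups at this position do not divide simply into halogens and non-halogens. Leaving dimethylamino gives an at least 14-fold lower number from compound 3 to compound 4 (1.17 log units; beyond the scatter) as a bound and not a size, for compound 3 is known only by a limit: the limit of > 400000 nM in this assay, at which 1 of the 4 values shown sits.

As far as these compounds go, how far compound 3 truly lies from compound 4 stays open. The compounds shown also do not tell whether the number seen with dimethylamino belongs to that group alone or would return with another amine such as morpholine or a free amino group, or with methoxy in the same place.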